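A few compounds are considered here, and "the series" means these few. Any claim that something is new, unique, unknown or untested is made for them only; others in the source may bear on it.

Measured so far:
Compound 1 `C[C@@H]1CN(c2sc(C(F)(F)F)nc2-c2nc3cc(OCCO)ccc3[nH]2)CCN1C(=O)Cn1cnc2cccnc21` gives 99.1 nM in a functional assay on Venous blood for antagonist activity at C-X-C chemokine receptor type 3 (Homo sapiens), read by flow cytometry, with a stated time of 30 min, in the presence of a further agent that is not named here; on this read-out lower numbers stand for stronger inhibition and higher numbers for weaker inhibition.
Compound 2 `C[C@@H]1CN(c2sc(C(F)(F)F)nc2-c2nc3ccccc3[nH]2)CCN1C(=O)Cn1cnc2c1CCN(C)C2` gives 135 nM in this assay.

Compound 2 has the highest of these two numbers, but its nearest neighbour, compound 1, lies within the usual scatter of the method, so the two cannot be told apart on these data.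

Compound 3 `C[C@@H]1CN(c2sc(C(F)(F)F)nc2-c2nc3ccccc3[nH]2)CCN1C(=O)Cn1cnc2cccnc21` has not yet been measured. Compared with compound 2 it carries a group of 9 heavy atoms (6 carbon, 3 nitrogen; one five-membered aromatic ring with 2 hetero atoms, one six-membered aromatic ring with 1 hetero atom) in place of a group of 10 heavy atoms (7 carbon, 3 nitrogen; one five-membered aromatic ring with 2 hetero atoms, one six-membered non-aromatic ring with 1 hetero atom), on a saturated chain carbon bound to a carbonyl carbon.

Among the measured compounds shown here, no step between two measured compounds has been recorded, so there is no direct precedent for a change of this kind. The two measured numbers sit close together, and nothing in them points to a large shift in either direction. For compound 3 in this assay the expected outcome is a number close to that of compound 2, with the estimated step of a 1.4-fold lower number from compound 2 to compound 3 (0.13 log units; within the scatter) lying within the scatter. Compound 3 is therefore estimated at 100 nM, in a range from 45 nM to 220 nM.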

Compound 3, half-maximal inhibitory concentration in the C-X-C chemokine receptor type 3 assay: 70 nM
Estimate against measurement, compound 3: 1.4-fold (0.15 log units) above, within the range that was stated.
By their numbers in the C-X-C chemokine receptor type 3 assay, from the lowest: compounds 3, 1 and 2 (each within the scatter of the next).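

In the C-X-C chemokine receptor type 3 assay, putting the group with a six-membered aromatic ring in place of the one with a six-membered non-aromatic ring, on a saturated chain carbon bound to a carbonyl carbon, gives a 1.9-fold lower number from compound 2 to compound 3 (0.29 log units; within the scatter), while hydrogen in place of 2-hydroxyethoxy on an aromatic carbon gives a 1.4-fold lower number from compound 1 to compound 3 (0.15 log units; within the scatter); neither step can be told from scatter. In a physicochemical assay for lipophilicity, at pH 7.4 (on this read-out lower numbers stand for lower lipophilicity and higher numbers for higher lipophilicity), compound 2 gives 3 and compound 3 gives 3.9. This group change therefore separates the two compounds in lipophilicity but not in inhibition: the measured distribution coefficient of compound 2, 3, and of compound 3, 3.9, a number 0.90 log units higher (beyond the scatter)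

From the compounds shown here alone, it remains open whether a morpholine ring at the saturated chain carbon would also leave inhibition within the scatter. Also open, going by these compounds, is whether a longer chain than 2-hydroxyethoxy, or a carboxylic acid, on the aromatic carbon would give a step beyond the scatter.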